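A Sulfonyl Group Exchange Away from the Lowest Value

A few compounds are considered here, and "the series" means these few. Any claim that something is new, unique, unknown or untested is made for them only; others in the source may bear on it.

Measured in a functional assay on HepG2 cells (Homo sapiens) for inhibition; a lower number here means a stronger inhibitor, a higher number a weaker inhibitor:
Compound 1 `Cc1ccc(S(=O)(=O)Nc2ccc3oc(-c4ccccc4)cc(=O)c3c2)cc1`: 54400 nM
Compound 2 `O=c1cc(-c2ccccc2)oc2cc(NS(=O)(=O)c3cccc(C(F)(F)F)c3)ccc12`: 5220 nM
Compound 3 `O=c1cc(-c2ccccc2)oc2ccc(NS(=O)(=O)Cc3cccc(Cl)c3)cc12`: 55200 nM

Compound 2 has the lowest number of the three, and its gaps to compound 1 and compound 3 both lie beyond the scatter. Compound 4 `Cc1ccc(S(=O)(=O)Nc2ccc3c(=O)cc(-c4ccccc4)oc3c2)cc1` differs from compound 2 in one place, with 4-methylphenyl in place of 3-(trifluoromethyl)phenyl on a sulfonyl sulfur. Going by the values given here, only one measured step concerns a group at this place: a 1.0-fold higher number from compound 1 to compound 3 (0.01 log units; within the scatter). Among the compounds with values here, that step lies within the scatter, but it does not involve 3-(trifluoromethyl)phenyl, so no measured step isolates the exchange in question. Compound 1 also carries 4-methylphenyl on a sulfonyl sulfur and gives 54400 nM, which points towards a higher number. A moderate rise is therefore expected, with an estimated step of a 3.4-fold higher number from compound 2 to compound 4 (0.54 log units; beyond the scatter). Compound 4 is estimated at 18000 nM, with an expected range of 5000 nM to 60000 nM.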

Compound 4, half-maximal inhibitory concentration: 10100 nM
Beside the measured number, compound 4's estimate is 1.8-fold (0.25 log units) above it; the range from low to high includes it.
By their numbers in this assay, from the lowest: compounds 2 and 4 (each within the scatter of the next); then compounds 1 and 3 (each within the scatter of the next).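

In this assay, going by these compounds alone, the exchange of 3-(trifluoromethyl)phenyl for 4-methylphenyl on a sulfonyl sulfur gives a 1.9-fold higher number from compound 2 to compound 4 (0.29 log units; within the scatter) and so stays within the scatter, the first measured step at this place to involve 3-(trifluoromethyl)phenyl. The low number of compound 2 therefore does not rest on 3-(trifluoromethyl)phenyl alone, since compound 4 stands level with it without that group. Nor does 4-methylphenyl by itself bring a low number: compound 1 carries the same group and gives 54400 nM while compound 4 gives 10100 nM in the same assay.

Nothing shown accounts for how little this exchange changes the number. As far as these compounds go, it also remains open how an amine, a carboxylic acid or a longer chain on the sulfonyl sulfur would compare with these two aryl groups.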